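Aminophenyl in Place of Aminopyridinyl on the Amide Nitrogen

The source may hold more compounds than are shown below. What is called first, only, known or untested is meant among the compounds shown, and "the series" means these compounds.

This account follows a small series measured in a functional assay on MGC-803 cells (Homo sapiens) for antiproliferative activity, read by CCK-8 assay, with a stated time of 72 h; a higher number here means a weaker inhibitor, a lower number a stronger inhibitor. Compound 1 `O=C(/C=C/c1ccc(COc2ccccc2)cc1)NO` carries a hydroxamic acid on the shared core; its value in this assay is "not determined" (no result reported). Compound 2 `Nc1ccccc1NC(=O)/C=C/c1ccc(CN2CCc3ccccc32)cc1` reaches only the limit of this assay, giving > 32000 nM. Compound 3 `Nc1cnccc1NC(=O)/C=C/c1ccc(COc2ccccc2)cc1` likewise stops at the limit, giving > 32000 nM in this assay. For the measured compounds named here, compound 3 therefore stands at the edge of what the assay reports, with no single number of its own, and the one other value shown sits at the same limit (the limit of > 32000 nM in this assay, at which 2 of the 3 values shown sit).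

Compound 4 `Nc1ccccc1NC(=O)/C=C/c1ccc(COc2ccccc2)cc1` differs from compound 3 in one place: 2-aminophenyl in place of 3-aminopyridin-4-yl on an amide-type nitrogen. Going by the values given here, no step between measured compounds is available to calibrate this change, so the expectation rests on the structural change alone. The author expects compound 4 to move below the limit by a modest margin, a step from compound 3 to compound 4 of an at least 2.6-fold lower number from compound 3 to compound 4 (0.42 log units; beyond the scatter), though it may remain at the limit. The estimate for compound 4 in this assay is 12000 nM, ranging from 2500 nM to 40000 nM.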

Compound 4, half-maximal inhibitory concentration: > 32000 nM
Compound 4: no number, only a limit; the forecaster's own chance of this, stated with the estimate: 40%; at least 2.6-fold (0.42 log units) between middle value and limit.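

Compound 4 also stops at a limit, so the steps to it from compound 3 and from compound 2 cannot be read in this assay: the limit of > 32000 nM in this assay, at which 3 of the 4 values shown sit. The compounds shown leave open whether 2-aminophenyl and 3-aminopyridin-4-yl on the amide-type nitrogen differ at all in this assay.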